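A few compounds are considered here, and "the series" means these few. Any claim that something is new, unique, unknown or untested is made for them only; others in the source may bear on it.

Of the compounds shown here, three have been measured so far in a physicochemical assay for solubility; a lower number here means a less soluble compound, a higher number a more soluble compound. Compound 1 `O=S(=O)(Nc1ncccn1)c1ccc2c(c1)OCC[C@@H]2c1ccc(C(F)(F)F)cc1-c1ccc(F)nc1` gives 408000 nM, compound 2 `Cc1nc(-c2cc(C(F)(F)F)ccc2[C@H]2CCOc3cc(S(=O)(=O)Nc4cccc(F)n4)ccc32)co1` gives 13000 nM, and compound 3 `O=S(=O)(Nc1ncccn1)c1ccc2c(c1)CC[C@@H]2c1ccc(C(F)(F)F)cc1-c1ccc(F)nc1` gives 40000 nM. Compound 3 thus holds the second highest of the three numbers, and its gaps to compound 2 and compound 1 both lie beyond the usual scatter of repeat measurements.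

Compound 4 `Cn1nccc1-c1cc(C(F)(F)F)ccc1[C@H]1CCc2cc(S(=O)(=O)Nc3ncccn3)ccc21` has not been measured yet. It differs from compound 3 in one place: 1-methyl-1H-pyrazol-5-yl in place of 6-fluoropyridin-3-yl on an aromatic carbon. Here 1-methyl-1H-pyrazol-5-yl stands in place of 6-fluoropyridin-3-yl on an aromatic carbon, ortho to a large group and meta to a trifluoromethyl group.

Among the measured compounds shown here, no pair of measured compounds shows this change on its own, so the expectation rests on thin evidence and the range must stay wide. The expected change is small and upward, if there is one at all, with an estimated 1.4-fold higher number from compound 3 to compound 4 (0.14 log units; within the scatter) that stays within the scatter. The estimated value for compound 4 is 55000 nM, with an expected range of 12000 nM to 250000 nM.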

Compound 4, solubility: 316000 nM
Estimate against measurement, compound 4: 5.7-fold (0.76 log units) below, outside the stated range (above it).
By their numbers in this assay, from the lowest: compound 2; then compound 3; then compounds 4 and 1 (each within the scatter of the next).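

At this position, ortho to a large group and meta to a trifluoromethyl group, the choice of aromatic ring matters in this assay. Putting 1-methyl-1H-pyrazol-5-yl in place of 6-fluoropyridin-3-yl gives a 7.9-fold higher number from compound 3 to compound 4 (0.90 log units; beyond the scatter) as the first single-place change available, showing that swapping one ring here can by itself move the number well beyond the scatter. Nothing measured here accounts for the rise, so its cause remains unknown.

Still open, going by these compounds, is whether the step belongs to the five-membered ring itself or to its methyl group, and whether the same swap would act alike on the core of compound 1. How an amine or a carboxylic acid on this same aromatic carbon would compare also remains an open question.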